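From bromo to hydrogen on compound 1

The source may report more compounds than this note shows. Statements on the series, on what has been measured and on what is new or still open speak of the compounds shown alone.

Measured in a functional assay on RKO cells (Homo sapiens) for cytotoxicity, read by resazurin assay, with a stated time of 72 h; on this read-out lower numbers stand for stronger inhibition and higher numbers for weaker inhibition:
- compound 1 `Cc1nccn1-c1csc(Nc2cccc(Br)c2)n1`: > 100000 nM (a limit)
- compound 2 `c1ccc(Nc2nc(-n3cnc4ccccc43)cs2)cc1`: > 100000 nM (a limit)
- compound 3 `Cc1nc2ccccc2n1-c1csc(Nc2ccc(Br)cc2)n1`: 90 nM

Compound 1 sits at the limit of > 100000 nM in this assay, at which 2 of the 3 values shown sit. Its reading is a limit and not a number, so it marks no exact starting point. Compound 3 is the only one of the three with a numerical value, and it differs from compound 1 in more than one place.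

The next compound is compound 4 `Cc1nccn1-c1csc(Nc2ccccc2)n1`, which is compound 1 with hydrogen in place of bromo on an aromatic carbon. For the measured compounds named here, no measured pair isolates this change, so its size in this assay can only be estimated. The closest guide is compound 2, which also has no bromo and reads > 100000 nM, again a limit. Compound 3 does carry a bromo, but its other differences mean that it cannot show what the bromo alone contributes. No clear gain in potency is therefore expected, and the estimated at least 1.1-fold lower number from compound 1 to compound 4 (0.04 log units; that floor lies within the scatter) is expected to stay within the usual scatter. Compound 4 is expected to give about 90000 nM, with an estimated range from 20000 nM to 150000 nM.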

Compound 4, half-maximal inhibitory concentration: 32500 nM
Estimate against measurement, compound 4: 2.8-fold (0.44 log units) above; the measured number falls inside the stated range.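

In this assay, hydrogen in place of bromo on an aromatic carbon, meta to a large group, gives an at least 3.0-fold lower number from compound 1 to compound 4 (0.48 log units; beyond the scatter), a step beyond the usual scatter. This is the first pair shown that differs in one place only, and it shows that the bromo at this position of the six-membered aromatic ring of carbon only is not required for a numerical reading, since its removal goes with a lower number. The size of the step is a floor and not an exact figure, since compound 1 carries a limit and not a number: the limit of > 100000 nM in this assay, at which 2 of the 4 values shown sit.

The compounds shown leave open how this same position responds to other groups, such as a chlorine, a methoxy group or an amine, and so whether the bromo itself or simply any group there goes with the higher number. Compound 3, at 90 nM, remains well apart from this pair, and as it differs from compound 4 in more than one place, what sets its value remains unresolved.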